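Swapping a Methoxy for a Hydroxy on an Inactive Scaffold

The compounds below may be only part of what the source reports. "The series", "measured", "known", "first", "only" and "open" are said of these compounds alone.

Compound 2 `COc1ccccc1-c1cn(C/C=C2\OC(=O)C(OCc3ccccc3)=C2OCc2ccccc2)nn1` was examined in a functional assay on SW-620 cells (Homo sapiens) for antiproliferative activity, read by MTT assay, with a stated time of 72 h; a higher number here means a weaker inhibitor, a lower number a stronger inhibitor. In this assay compound 2 gives only a limit of > 100000 nM, not a number. Its neighbour compound 1 `Cc1ccc(-c2cn(C/C=C3\OC(=O)C(OCc4ccccc4)=C3OCc3ccccc3)nn2)cc1` also stops at a limit, > 100000 nM. The step that the two limits leave unreadable from compound 1 to compound 2 is therefore unreadable, because both values rest at the same limit (the limit of > 100000 nM in this assay, at which 2 of the 2 values shown sit). Compound 3 `O=C1O/C(=C\Cn2cc(-c3cccc(O)c3)nn2)C(OCc2ccccc2)=C1OCc1ccccc1` is the next variant: 3-hydroxyphenyl in place of 2-methoxyphenyl on an aromatic carbon. Among the measured compounds shown here, no measured step shows what a 3-hydroxyphenyl group does at this position, and the one measured step gives no size to build on. With both measured compounds at the limit, compound 3 is expected to stay near that limit as well, with an estimate of 100000 nM and a plausible range of 30000 nM to 300000 nM. That estimate implies a step of a number no higher from compound 2 to compound 3 (the limit leaves the size open), expected to remain within the scatter.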

Compound 3, half-maximal inhibitory concentration: 69800 nM
Compound 3: the middle estimate sits 1.4-fold (0.16 log units) above what was measured; low and high end bracket the measured number.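

Among the compounds shown here, on the shared core, the 3-hydroxyphenyl group is the first group at this position to give a readable number: in this assay compound 3 gives 69800 nM. Replacing the 2-methoxyphenyl group gives an at least 1.4-fold lower number from compound 2 to compound 3 (0.15 log units; that floor lies within the scatter), and replacing the 4-methylphenyl group gives an at least 1.4-fold lower number from compound 1 to compound 3 (0.15 log units; that floor lies within the scatter). On these data alone, both steps are floors only, so their true size stays open, and the step from compound 1 to compound 2 cannot be read, because two of the values are limits: the limit of > 100000 nM in this assay, at which 2 of the 3 values shown sit.

Compound 3 differs from compound 2 in both the hydroxy group and its place on the phenyl ring, so the compounds shown do not separate these two changes. As far as these compounds go, the effect of a 3-methoxyphenyl group, or of an amine or a carboxylic acid on that phenyl ring, also remains open.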